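Acetamide to pyridyl urea on the shared core

The source may report more compounds than this note shows. Statements on the series, on what has been measured and on what is new or still open speak of the compounds shown alone.

compound 1 `CN1CCN(Cc2cc3nc(-c4ccc(NC(=O)Nc5cccnc5)cc4)nc(N4CC5CCC(C4)O5)c3s2)CC1`: 148 nM
compound 2 `CC(=O)Nc1ccc(-c2nc(N3CC4CCC(C3)O4)c3sccc3n2)cc1`: 1700 nM

In a functional assay on LNCaP cells (Homo sapiens) for cytotoxicity (a higher number here means a weaker inhibitor, a lower number a stronger inhibitor), compound 2 gives 1700 nM, the highest of the two numbers, while compound 1 gives 148 nM, a lower number beyond the scatter. Compound 3 `O=C(Nc1ccc(-c2nc(N3CC4CCC(C3)O4)c3sccc3n2)cc1)Nc1cccnc1` follows from compound 2 by (pyridin-3-yl)amino in place of methyl on a carbonyl carbon. Within the data shown here, no step between measured compounds covers this change alone; compound 1 carries the same urea on the shared core together with a further substituent, so its number guides only loosely. The step of a 4.9-fold lower number from compound 2 to compound 3 (0.69 log units; beyond the scatter) is expected to be a clear decrease, beyond the scatter. Compound 3 is estimated at 350 nM, within 100 nM to 1200 nM.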

Compound 3, half-maximal inhibitory concentration: 27 nM
Compound 3: the middle estimate sits 13-fold (1.11 log units) above what was measured, and the stated range ends above it.
By their numbers in this assay, from the lowest: compound 3; then compound 1; then compound 2.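

In this assay (pyridin-3-yl)amino in place of methyl on the carbonyl carbon gives a 63-fold lower number from compound 2 to compound 3 (1.80 log units; beyond the scatter) on its own, with no further substituent on the shared core, which compound 1 could not show. Hydrogen in place of (4-methylpiperazin-1-yl)methyl on the aromatic carbon gives a 5.5-fold lower number from compound 1 to compound 3 (0.74 log units; beyond the scatter) as a modest further step, so that group is not needed for the low number here. Nothing available gives a reason for either step.

Open, going by these compounds, is whether the step belongs to the urea itself or to the pyridine ring. A phenylamino or methylamino group on the same carbonyl carbon would separate the two.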